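Chloro for Fluoro at the Assay Limit

This account rests on a few compounds, and the source may have more. Where it says the series, first, only, none or still open, it means among the compounds named here.

Measured so far in an ADME assay on microsomes from liver (Rattus norvegicus) for metabolic stability; a higher number here means that the compound lasts longer, a lower number that the compound disappears faster:
- compound 1 `Clc1ccc(-c2nc(NCCNc3ccccn3)ncc2-c2ncc[nH]2)c(Cl)c1`: > 0.5 h
- compound 2 `Nc1nc(NCCNc2ncc(-c3ncc[nH]3)c(-c3ccc(F)cc3F)n2)ccc1[N+](=O)[O-]`: > 0.5 h

Compound 2 stands at > 0.5 h, which is a limit of the assay and not a number. Compound 1 offers no contrast, as both compounds share one reading: the limit of > 0.5 h in this assay, at which 2 of the 2 values shown sit. Compound 3 `Nc1nc(NCCNc2ncc(-c3ncc[nH]3)c(-c3ccc(Cl)cc3F)n2)ccc1[N+](=O)[O-]` changes one group of compound 2, turning 2,4-difluorophenyl into 4-chloro-2-fluorophenyl: chloro in place of fluoro on an aromatic carbon. For the measured compounds named here, no measured pair shows this swap, so only a modest expectation is possible in this assay, with no firm direction and nothing beyond the scatter. The expected step, a step that the limit leaves unreadable from compound 2 to compound 3, is therefore small. For compound 3 the estimated half-life is 0.7 h, with an expected range of 0.35 h to 1.4 h.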

Compound 3, half-life: > 0.5 h
Compound 3: no number, only a limit; the forecaster's own chance of this, stated with the estimate: 70%; the middle value lies beyond the limit too.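

No step can be read between compound 2 and compound 3, since both rest on one reading: the limit of > 0.5 h in this assay, at which 3 of the 3 values shown sit. The compounds shown leave open how long each actually lasts, and whether chloro in place of fluoro changes that at all.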